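The source may report more compounds than this note shows. Statements on the series, on what has been measured and on what is new or still open speak of the compounds shown alone.

Measured so far, in a functional assay on HEK293 cells for positive allosteric modulation of metabotropic glutamate receptor 5 (Rattus norvegicus), read by fluorescence and calcium flux; a higher number here means a larger maximal response, a lower number a smaller maximal response:
compound 1 `C[C@@H](NC(=O)c1ccc(C#Cc2ccc(F)cc2F)cn1)C(C)(C)O` gives 61.2%
compound 2 `C[C@@H](NC(=O)c1ccc(C#Cc2cccnc2)cn1)C(C)(C)O` gives 71.5%
compound 3 `C[C@@H](NC(=O)c1ccc(C#CC2CCCC2)cn1)C(C)(C)O` gives 63.7%

Compound 3 stands second highest of the three numbers, with compound 1 nearest and compound 2 furthest, both gaps within the scatter. Compound 4 `C[C@@H](NC(=O)c1ccc(C#Cc2ccc(F)cn2)cn1)C(C)(C)O` differs from compound 3 at one place only: 5-fluoropyridin-2-yl in place of cyclopentyl on a triple-bonded carbon. Going by the values given here, the steps that bear on this are the earlier exchanges on the same triple-bonded carbon. Moving from an aromatic ring to cyclopentyl gave a number 2.5 percentage points higher from compound 1 to compound 3 (within the scatter) and a number 7.8 percentage points lower from compound 2 to compound 3 (within the scatter), neither beyond the scatter; only a number 10.3 percentage points higher from compound 1 to compound 2 (beyond the scatter) exceeded it. The entering group is again a six-membered aromatic ring with one hetero atom, as in compound 2, and carries a fluorine, as in compound 1, so in this assay no step beyond the scatter is expected; the expected shift is a number 3.3 percentage points higher from compound 3 to compound 4 (within the scatter). Compound 4 is estimated at 67%, with a range of 55% to 79%.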

Compound 4, largest response reached (reported as efficacy), in percent of the reference or control that the assay uses: 64.6%
Compound 4: middle estimate off by 2.4 percentage points, on the high side, and the stated range covers the measured number.
By their numbers in this assay, from the lowest: compounds 1, 3, 4 and 2 (each within the scatter of the next, the first and the last beyond it).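

In this assay, 5-fluoropyridin-2-yl on the triple-bonded carbon stays within the scatter of all three earlier groups: a number 0.9 percentage points higher from compound 3 to compound 4 (within the scatter) and a number 6.9 percentage points lower from compound 2 to compound 4 (within the scatter) and a number 3.4 percentage points higher from compound 1 to compound 4 (within the scatter). Compound 4 thus bridges the only gap beyond the scatter at this position, a number 10.3 percentage points higher from compound 1 to compound 2 (beyond the scatter), so these four compounds do not fall into two separate sets. No measurement shown gives a reason for these numbers.

From the compounds shown here alone, how an amine or a longer alkyl chain on this carbon would read remains open. So does any change elsewhere on the shared core, as all four compounds differ at this one place.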